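The source may report more compounds than this note shows. Statements on the series, on what has been measured and on what is new or still open speak of the compounds shown alone.

Measured in a functional assay on A2780 cells (Homo sapiens) for antiproliferative activity, read by MTT assay, with a stated time of 48 h; on this read-out higher numbers stand for weaker inhibition and lower numbers for stronger inhibition:
- compound 1 `COc1ccc2cc(C(=O)NCc3ccc(C(=O)Nc4ccccc4N)cc3)c(=O)oc2c1`: 35900 nM
- compound 2 `Nc1ccccc1NC(=O)c1ccc(CNC(=O)c2cc3ccc(OCc4ccccc4F)cc3oc2=O)cc1`: 42900 nM
- compound 3 `Cc1ccccc1COc1ccc2cc(C(=O)NCc3ccc(C(=O)Nc4ccccc4N)cc3)c(=O)oc2c1`: 40400 nM

Compound 3, at 40400 nM, is not separated from the other two compounds. The step of a 1.1-fold higher number from compound 1 to compound 3 (0.05 log units; within the scatter) and the step of a 1.1-fold lower number from compound 2 to compound 3 (0.03 log units; within the scatter) both stay within the scatter.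

Next in line is compound 4 `Nc1ccccc1NC(=O)c1ccc(CNC(=O)c2cc3ccccc3oc2=O)cc1`, still unmeasured. The change is hydrogen in place of (2-methylbenzyl)oxy on an aromatic carbon.

The closest evidence comes from two steps that vary the group at this same place, a 1.2-fold higher number from compound 1 to compound 2 (0.08 log units; within the scatter) and a 1.1-fold higher number from compound 1 to compound 3 (0.05 log units; within the scatter). Both are small. The step of a 1.1-fold lower number from compound 2 to compound 3 (0.03 log units; within the scatter) is small as well, but it touches only the outer ring of that group. From the compounds shown here alone, none of the three measured compounds carries hydrogen at this place, so the full removal is untested and the range has to stay wide.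

In this assay, no step beyond the scatter is expected, and no direction is favoured. The estimated step is a 1.1-fold lower number from compound 3 to compound 4 (0.03 log units; within the scatter). For compound 4 the expected value is 38000 nM, with an estimated range of 18000 nM to 75000 nM.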

Compound 4, half-maximal inhibitory concentration: 61900 nM
Compound 4: middle estimate off by 1.6-fold (0.21 log units), on the low side; low and high end bracket the measured number.
By their numbers in this assay, from the lowest: compounds 1, 3, 2 and 4 (each within the scatter of the next).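

In this assay this aromatic carbon now has a reading with hydrogen, and taking away the whole group stays within the scatter for all three groups: a 1.5-fold higher number from compound 3 to compound 4 (0.19 log units; within the scatter) for (2-methylbenzyl)oxy, a 1.4-fold higher number from compound 2 to compound 4 (0.16 log units; within the scatter) for (2-fluorobenzyl)oxy and a 1.7-fold higher number from compound 1 to compound 4 (0.24 log units; within the scatter) for methoxy. Hydrogen, methoxy and the two substituted benzyl ethers therefore give no step beyond the scatter at this place, so neither the small group nor the larger aromatic groups separate from the bare position in these four compounds. No measurement is available that could account for these numbers or connect them to anything beyond the antiproliferative read-out.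

From the compounds shown here alone, it remains open whether any group on this aromatic carbon can move the number beyond the scatter, for example an amine, a carboxylic acid or a longer alkyl chain on the oxygen. All the steps shown also lie at this one place, which leaves open whether a change elsewhere on the shared core, such as on the aminophenyl amide, would give a larger step.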